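Amino for Hydroxy on the Side Chain of Compound 2

The source may hold more compounds than are shown below. What is called first, only, known or untested is meant among the compounds shown, and "the series" means these compounds.

In an assay on cells for antagonist activity at transient receptor potential cation channel subfamily V member 4 (Homo sapiens), read by FLIPR and calcium flux, with a stated time of 10 min (on this read-out higher numbers stand for weaker inhibition and lower numbers for stronger inhibition), compound 2 `N#Cc1ccc(S(=O)(=O)N2C[C@H](S(=O)(=O)c3ccc(Cl)cn3)[C@](O)(CO)C2)c(Cl)c1` gives 5 nM, the second highest of the three numbers measured. Compound 1 `N#Cc1ccc(S(=O)(=O)[C@H]2CN(S(=O)(=O)c3ccc(C#N)cc3Cl)C[C@@]2(O)CO)cc1` gives 3.2 nM, and a 1.6-fold higher number from compound 1 to compound 2 (0.19 log units; within the scatter). Compound 3 `N#Cc1ccc(S(=O)(=O)N2C[C@H](S(=N)(=O)c3ccc(Cl)cc3)[C@](O)(CO)C2)c(Cl)c1` gives 20 nM, and a 4.0-fold higher number from compound 2 to compound 3 (0.60 log units; beyond the scatter). Compound 4 `N#Cc1ccc(S(=O)(=O)N2C[C@H](S(=O)(=O)c3ccc(Cl)cn3)[C@](O)(CN)C2)c(Cl)c1` differs from compound 2 by amino in place of hydroxy on a saturated chain carbon bound to a saturated ring carbon. Neither measured step touches this position: the step from compound 1 to compound 2 changes a ring on the sulfonyl sulfur, and the step from compound 2 to compound 3 changes a group on a saturated ring carbon. Among the measured compounds shown here, no measured step therefore bears directly on the change, and the expectation rests on compound 2 alone, with wide bounds and no direction that can be read from the data. Compound 4 is expected to give 8 nM, between 3 nM and 30 nM. Compound 4 is thus expected at a 1.6-fold higher number from compound 2 to compound 4 (0.20 log units; within the scatter).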

Compound 4, half-maximal inhibitory concentration: 0.5 nM
Compound 4: the middle estimate sits 16-fold (1.20 log units) above what was measured, and the stated range ends above it.
By their numbers in this assay, from the lowest: compound 4; then compounds 1 and 2 (each within the scatter of the next); then compound 3.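

In this assay the change from hydroxymethyl to aminomethyl gives a 10-fold lower number from compound 2 to compound 4 (1.00 log units; beyond the scatter) and so shows that this position, which neither earlier step touched, responds strongly to a single atom. The step lies beyond the scatter, although hydroxy and amino have the same counts of heavy atoms, hydrogen-bond donors and acceptors and the same net charge. Nothing available explains the step.

From the compounds shown here alone, whether a longer chain carrying the amine, or a carboxylic acid, would hold this level at that place remains open. So does whether amino for hydroxy gives a similar step with 4-cyanophenyl on the sulfonyl sulfur.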